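Carbamoyl for 3-aminopropyl: compound 3 to compound 4

The compounds below may be only part of what the source reports. "The series", "measured", "known", "first", "only" and "open" are said of these compounds alone.

In a functional assay on MT4 cells (Homo sapiens) for antiproliferative activity (a lower number here means that less compound is tolerated, a higher number that more compound is tolerated), compound 1 (`Cc1cn(C2OC(CO[Si](C)(C)C(C)(C)C)C3(OS(=O)(=O)C=C3N)C2O[Si](C)(C)C(C)(C)C)c(=O)n(CCCNC(=O)[C@@H]2CCCN2C(=O)[C@@H](N)C(C)C)c1=O`) gives 11000 nM and compound 2 (`Cc1cn(C2OC(CO[Si](C)(C)C(C)(C)C)C3(OS(=O)(=O)C=C3N)C2O[Si](C)(C)C(C)(C)C)c(=O)n(CCCNC(=O)[C@@H]2CCCN2C(=O)[C@H](C)N)c1=O`) gives 20000 nM while compound 3 (`Cc1cn(C2OC(CO[Si](C)(C)C(C)(C)C)C3(OS(=O)(=O)C=C3N)C2O[Si](C)(C)C(C)(C)C)c(=O)n(CCCNC(=O)[C@@H]2CCCN2C(=O)[C@@H](N)CCCCN)c1=O`) gives 87000 nM as the highest of the three numbers. Compound 4 (`Cc1cn(C2OC(CO[Si](C)(C)C(C)(C)C)C3(OS(=O)(=O)C=C3N)C2O[Si](C)(C)C(C)(C)C)c(=O)n(CCCNC(=O)[C@@H]2CCCN2C(=O)[C@@H](N)CC(N)=O)c1=O`) has no number yet. Compared with compound 3 it carries carbamoyl in place of 3-aminopropyl on a saturated chain carbon, two bonds along the chain from an amine nitrogen and a carbonyl carbon.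

Within the data shown here, two measured steps bear on this change, and both end at compound 3. They show a 4.4-fold higher number from compound 2 to compound 3 (0.64 log units; beyond the scatter) and a 7.9-fold higher number from compound 1 to compound 3 (0.90 log units; beyond the scatter) as modest steps beyond the scatter. The third step shows a 1.8-fold higher number from compound 1 to compound 2 (0.26 log units; within the scatter) and separates nothing. Among the measured compounds shown here, no measured compound carries carbamoyl, so the reading is uncertain. Compound 4 gives up the chain seen in compound 3, so a modest fall is expected. In this assay the expected step is a 2.9-fold lower number from compound 3 to compound 4 (0.46 log units; beyond the scatter) as an estimate. For compound 4 the estimate is 30000 nM with 11000 nM to 80000 nM as its expected range.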

Compound 4, half-maximal cytotoxic concentration: 22000 nM
Compound 4: middle estimate off by 1.4-fold (0.13 log units), on the high side; the measured number falls inside the stated range.
By their numbers in this assay, from the lowest: compounds 1, 2 and 4 (each within the scatter of the next); then compound 3.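

Working notes: in this assay, replacing the 3-aminopropyl extension at this position with carbamoyl gives a 4.0-fold lower number from compound 3 to compound 4 (0.60 log units; beyond the scatter), so the high number of compound 3 does not carry over to a side chain ending in carbamoyl. Compound 4 also stays level with the two compounds that have short side chains, with a 1.1-fold higher number from compound 2 to compound 4 (0.04 log units; within the scatter) and a 2.0-fold higher number from compound 1 to compound 4 (0.30 log units; within the scatter), so methyl, isopropyl and carbamoylmethyl are not separated here and, among these four compounds, only the 4-aminobutyl of compound 3 stands apart. No measurement shown here accounts for this difference.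

From the compounds shown here alone, it remains open whether the higher number in compound 3 follows the terminal amine or the chain length, as a plain butyl chain or a 3-aminopropyl side chain would test. A carboxylic acid at this position, such as carboxymethyl, would show whether the group at the end of the chain matters beyond carbamoyl.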